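Series notes: hydroxy to fluoro from compound 3 to compound 4

The source may hold more compounds than are shown below. What is called first, only, known or untested is meant among the compounds shown, and "the series" means these compounds.

In a functional assay on A549 cells (Homo sapiens) for antiproliferative activity, read by sulforhodamine B assay, with a stated time of 48 h (a lower number here means a stronger inhibitor, a higher number a weaker inhibitor), compound 1 (`COc1cc(OC)c2sc(-c3ccc(N/C=C\C(=O)c4ccc(OC)c(O)c4)c(C)c3)nc2c1`) gives 14300 nM, compound 2 (`COc1cc(C(=O)/C=C\Nc2ccc(-c3nc4cc(OC)c(OC)c(OC)c4s3)cc2C)cc([N+](=O)[O-])c1OC`) gives 17400 nM and compound 3 (`COc1ccc2nc(-c3ccc(N/C=C\C(=O)c4ccc(OC)c(O)c4)cc3)sc2c1`) gives 12800 nM. All three values lie within the scatter of one another, so compound 3 stands level with the other two. Compound 4 (`COc1ccc2nc(-c3ccc(N/C=C\C(=O)c4ccc(OC)c(F)c4)cc3)sc2c1`) differs from compound 3 in one place: fluoro in place of hydroxy on an aromatic carbon. The 3-hydroxy-4-methoxyphenyl becomes 3-fluoro-4-methoxyphenyl, with fluoro in place of hydroxy on an aromatic carbon, ortho to a methoxy group. Among the measured compounds shown here, no measured pair isolates this change, so the data offer no direct guide. In this assay, no shift beyond the scatter is expected, in either direction. The estimated change is a 1.1-fold higher number from compound 3 to compound 4 (0.04 log units; within the scatter). The estimate for compound 4 is 14000 nM, with an expected range of 6000 nM to 32000 nM.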

Compound 4, half-maximal inhibitory concentration: 900 nM
For compound 4 the middle estimate is 16-fold (1.19 log units) above the measured one; measured number below the stated range.
By their numbers in this assay, from the lowest: compound 4; then compounds 3, 1 and 2 (each within the scatter of the next).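

In this assay, fluoro in place of hydroxy on this aromatic carbon, ortho to a methoxy group, gives a 14-fold lower number from compound 3 to compound 4 (1.15 log units; beyond the scatter) and so sets compound 4 apart. Compound 1, compound 2 and compound 3 lie within the scatter of one another, and none of them showed that this position can move the number at all. No measurement here bears on the origin of this step.

On these data alone, whether the step follows from fluoro itself or from the absence of hydroxy stays open, and chloro or an amine at this carbon would help separate the two. As far as these compounds go, whether the same change carries over to the core of compound 1 also stays open.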